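This account rests on a few compounds, and the source may have more. Where it says the series, first, only, none or still open, it means among the compounds named here.

Compound 1 `Brc1ccc(C2=NN(C3=NC(c4ccccc4)CS3)C(c3ccc4ccccc4c3)C2)cc1` gives 20300 nM in a functional assay on HepG2 cells (Homo sapiens) for inhibition, read by CCK-8 assay, with a stated time of 48 h; a lower number here means a stronger inhibitor, a higher number a weaker inhibitor.
Compound 2 `Cc1ccc(C2=NN(C3=NC(c4ccccc4)CS3)C(c3cccc4ccccc34)C2)cc1` gives 10400 nM in this assay.

Both compounds share the same core and carry two aromatic groups on it, and they differ in more than one place, so no single change can be read from their pair. Compound 2 has the lower of the two numbers, but its gap to compound 1 lies within the scatter of the assay, so the two cannot be ranked against each other.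

Compound 3 `Brc1ccc(C2=NN(C3=NC(c4ccccc4)CS3)C(c3cccc4ccccc34)C2)cc1` has not been measured in this assay. It differs from compound 2 in one place: bromo in place of methyl on an aromatic carbon. This is the same exchange that separates compound 1 from a closer relative in the pair shown, with compound 1 carrying the bromo group.

For the measured compounds named here, with only two numbers in hand, the step from compound 2 to compound 3 is expected to be small, a 1.4-fold higher number from compound 2 to compound 3 (0.16 log units; within the scatter), and not beyond the scatter. Compound 3 is therefore estimated at 15000 nM, with a range from 6000 nM to 40000 nM.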

Compound 3, half-maximal inhibitory concentration: 15600 nM
The estimate for compound 3 lay 1.0-fold (0.02 log units) below the measured number; the range from low to high includes it.
By their numbers in this assay, from the lowest: compounds 2, 3 and 1 (each within the scatter of the next).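

In this assay, 4-bromophenyl in place of 4-methylphenyl gives a 1.5-fold higher number from compound 2 to compound 3 (0.18 log units; within the scatter), so on this aromatic carbon, para to a large group, the bromo and methyl groups cannot be told apart. For the compounds shown here, the new compound also gives the first single change at the other varied site: with the bromo group held constant, naphthalen-1-yl in place of naphthalen-2-yl on the saturated ring carbon gives a 1.3-fold lower number from compound 1 to compound 3 (0.11 log units; within the scatter), so the two attachments of the naphthalene group cannot be told apart either. Nothing available explains why these exchanges leave the number within the scatter.

As far as these compounds go, with only these small, uncharged groups at the para position, it remains open whether an amine or a carboxylic acid there would shift the number beyond the scatter. From the compounds shown here alone, it is equally open whether a group other than naphthalenyl on the saturated ring carbon would do so.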